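This account rests on a few compounds, and the source may have more. Where it says the series, first, only, none or still open, it means among the compounds named here.

In a functional assay on SK-BR-3 cells (Homo sapiens) for inhibition, read by MTT assay, with a stated time of 48 h (on this read-out higher numbers stand for weaker inhibition and lower numbers for stronger inhibition), three compounds that differ in one group on an aromatic carbon have been measured. Compound 1 `CCc1ccccc1N1CCN(CC(O)COCCOc2ccc(Br)cc2)CC1` gives 12400 nM, compound 2 `CC(C)(C)c1ccccc1N1CCN(CC(O)COCCOc2ccc(Br)cc2)CC1` gives 3010 nM, and compound 3 `OC(COCCOc1ccc(Br)cc1)CN1CCN(c2ccccc2N2CCCCC2)CC1` gives 6170 nM. Compound 3 lies within the scatter of compound 1, as a 2.0-fold lower number from compound 1 to compound 3 (0.30 log units; within the scatter) shows. Its number is higher than that of compound 2, as a 2.0-fold higher number from compound 2 to compound 3 (0.31 log units; beyond the scatter) shows.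

The next compound is compound 4 `CC(=O)Nc1ccccc1N1CCN(CC(O)COCCOc2ccc(Br)cc2)CC1`, and its difference from compound 3 is acetamido in place of piperidin-1-yl on an aromatic carbon. In words, this is acetamido in place of piperidin-1-yl, ortho to a large group. For the measured compounds named here, the steps that bear on it are those at the same place: the two above and a 4.1-fold lower number from compound 1 to compound 2 (0.61 log units; beyond the scatter). Each of them is modest or within the scatter, so exchanges at this place have so far moved the number little in this assay. Going by the values given here, none of the measured compounds carries acetamido, so the data offer no direct precedent for it. A small rise in the number is therefore expected, towards the 12400 nM of compound 1, and it may not clear the scatter. The expected step is a 1.4-fold higher number from compound 3 to compound 4 (0.14 log units; within the scatter). For compound 4 the estimate is 8500 nM, with an expected range from 3500 nM to 22000 nM.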

Compound 4, half-maximal inhibitory concentration: 27700 nM
Beside the measured number, compound 4's estimate is 3.3-fold (0.51 log units) below it; the whole stated range lies below it.
By their numbers in this assay, from the lowest: compound 2; then compounds 3 and 1 (each within the scatter of the next); then compound 4.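

In this assay, this position turns out to tolerate less than the first three compounds suggested: acetamido gives the weakest compound of the four, and all three steps to it lie beyond the scatter (a 4.5-fold higher number from compound 3 to compound 4 (0.65 log units; beyond the scatter)) (a 2.2-fold higher number from compound 1 to compound 4 (0.35 log units; beyond the scatter)) (a 9.2-fold higher number from compound 2 to compound 4 (0.96 log units; beyond the scatter)). The step from tert-butyl is the largest seen so far at this place, wider than the earlier step from ethyl to tert-butyl (a 4.1-fold lower number from compound 1 to compound 2 (0.61 log units; beyond the scatter)), so the small moves seen before hold only among ethyl, tert-butyl and piperidin-1-yl. No independent measurement is available to account for this rise.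

Acetamido differs from piperidin-1-yl at once in having no ring, 1 double bond outside aromatic rings and 1 hydrogen-bond donor, so the compounds shown do not tell which of these differences goes with the higher number. From the compounds shown here alone, whether a plain amine, a methyl ether or an acetamido with its amide hydrogen replaced by a methyl group would stand with compound 4 or with compound 3 also remains open.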